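Replacing Benzylamino with Dipropylamino on the Shared Core

This account rests on a few compounds, and the source may have more. Where it says the series, first, only, none or still open, it means among the compounds named here.

Compound 1, `O=C1C=C(NCc2ccccc2)C(=O)c2c1nc1n2[C@H]2OC[C@@H](O)[C@H]2OC1`: in a functional assay on HeLa cells (Homo sapiens) for inhibition, read by sulforhodamine B assay (on this read-out higher numbers stand for weaker inhibition and lower numbers for stronger inhibition), compound 1 gives > 8000 nM, which is a limit of the assay and not a number.
Compound 2, `O=C1C(N2CCC2)=CC(=O)c2c1nc1n2[C@H]2OC[C@@H](O)[C@H]2OC1`: in this assay compound 2 gives > 16000 nM, again a limit of the assay rather than a measured number.

Compound 1 therefore stands at the limit of > 8000 nM in this assay, at which 1 of the 2 values shown sits, and compound 2 sits at the limit of > 16000 nM in this assay, at which 1 of the 2 values shown sits. Among the compounds with values here, the two values show only that neither compound reaches measurable inhibition within the range the assay resolves; no step between them can be read, and no measured step between compounds differing in one place is available at all.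

Compound 3, `CCCN(CCC)C1=CC(=O)c2nc3n(c2C1=O)[C@H]1OC[C@@H](O)[C@H]1OC3`, has not yet been tested in this assay. It differs from compound 1 in a single place: dipropylamino in place of benzylamino on a double-bonded ring carbon. Within the data shown here, with no measured step of this kind to lean on, the only anchor is compound 1 at the limit of > 8000 nM in this assay, at which 1 of the 2 values shown sits. The step that the limit leaves unreadable from compound 1 to compound 3 is expected to be none beyond the scatter, in no particular direction. Compound 3 is accordingly estimated to give 12000 nM, with a range from 4000 nM to 40000 nM, and a limit rather than a number is the more likely report.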

Compound 3, half-maximal inhibitory concentration: > 16000 nM
Compound 3 ended at the assay's limit; the forecaster's own chance of this, stated with the estimate: 70%; middle value at least 1.3-fold (0.12 log units) from the limit.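

In this assay, within the data shown here, compound 3, like compound 1, ended at a limit of the assay and not at a number, so no step between compound 1 and compound 3 can be read. The compounds shown leave open how strongly any of them inhibits, and whether dipropylamino in place of benzylamino changes that inhibition at all.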